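Urea aryl swap on the shared core: limits expected

The source may hold more compounds than are shown below. What is called first, only, known or untested is meant among the compounds shown, and "the series" means these compounds.

Compound 2 `COc1cc(-c2nn(-c3cccc(NC(=O)Nc4ccc(Cl)c(Cl)c4)c3)cc2-c2ccncc2)ccc1Cl` is a urea on the shared core. In a functional assay on SN12C cells (Homo sapiens) for inhibition, read by sulforhodamine B assay, with a stated time of 48 h (a higher number here means that more compound is tolerated, a lower number that less compound is tolerated), compound 2 gives only a limit, > 50000 nM (the limit of > 50000 nM in this assay, at which 1 of the 2 values shown sits). Compound 1 `O=C(Nc1cccc(-n2cc(-c3ccncc3)c(-c3ccc(Cl)c(O)c3)n2)c1)Nc1cccc(C(F)(F)F)c1` likewise gives only a limit in this assay, > 32500 nM (the limit of > 32500 nM in this assay, at which 1 of the 2 values shown sits). With both values limits, the two compounds cannot be ordered. Compound 3 `COc1cc(-c2nn(-c3cccc(NC(=O)Nc4cccc(C(F)(F)F)c4)c3)cc2-c2ccncc2)ccc1Cl` is unmeasured and differs from compound 2 by 3-(trifluoromethyl)phenyl in place of 3,4-dichlorophenyl on an amide-type nitrogen. Compound 1 already carries the 3-(trifluoromethyl)phenyl urea and reports a limit, > 32500 nM. For the step from compound 2 to compound 3 no shift beyond the scatter is expected, a number no higher from compound 2 to compound 3 (the limit leaves the size open). Compound 3 is therefore estimated at 50000 nM (20000 nM to 150000 nM), most likely returned as a limit.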

Compound 3, concentration lethal to 50% of the cells: > 50000 nM
Compound 3 was reported as a limit; the forecaster's own chance of this, stated with the estimate: 85%; the middle value sits exactly at the limit.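

Within the data shown here, with compound 1, compound 2 and compound 3 all reported as limits in this assay, no step among them can be read. Going by these compounds, whether either swap on the shared core shifts the read-out at all stays open.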